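What 1-carboxy-2-methylbutyl may do to compound 3

This account rests on a few compounds, and the source may have more. Where it says the series, first, only, none or still open, it means among the compounds named here.

Within the data shown here, in a functional assay on Caco-2 cells (Homo sapiens) for antiproliferative activity, read by MTT assay, with a stated time of 48 h (on this read-out lower numbers stand for stronger inhibition and higher numbers for weaker inhibition), compound 2 (`CCOC(=O)C(CC(=O)OC)NC(=O)c1ccc(C(CC)(CC)c2ccc(OCCC(O)(CC)CC)c(C)c2)n1CC`) gives 3020 nM as the only true number so far. Compound 1 (`C#CC(C)OC(=O)c1ccc(C(CC)(CC)c2ccc(OCCC(O)(CC)CC)c(C)c2)n1CC`) stands at > 50000 nM as a limit of the assay and not a number. Among the measured compounds shown here, the single measured step is an at least 16-fold lower number from compound 1 to compound 2 (1.21 log units; beyond the scatter) and it shows that replacing a group on a carbonyl carbon can matter greatly in this assay for this family.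

Compound 3 (`CCC(C)C(NC(=O)c1ccc(C(CC)(CC)c2ccc(OCCC(O)(CC)CC)c(C)c2)n1CC)C(=O)O`) keeps the shared core and changes part of the group that this step introduced. The change is a group of 8 heavy atoms (6 carbon, 2 oxygen; no ring) in place of a group of 11 heavy atoms (7 carbon, 4 oxygen; no ring), on an amide-type nitrogen and the group that enters is 1-carboxy-2-methylbutyl. The earlier step swapped different groups, so it warns that large moves are possible here but cannot set the size of this one. A modest move toward weaker inhibition is expected, with real doubt about the direction. The expected change is a 2.3-fold higher number from compound 2 to compound 3 (0.37 log units; beyond the scatter) and this is only an estimate. The estimate for compound 3 is 7000 nM within an expected range of 1500 nM to 35000 nM for now.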

Compound 3, half-maximal inhibitory concentration: 20000 nM
The estimate for compound 3 lay 2.9-fold (0.46 log units) below the measured number, within the range that was stated.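

In this assay, the group on the amide-type nitrogen turns out to matter in its own right: with 1-carboxy-2-methylbutyl entering, the result is a 6.6-fold higher number from compound 2 to compound 3 (0.82 log units; beyond the scatter). An amide at this carbonyl carbon therefore does not fix the number, since two different groups on the same nitrogen give clearly different values, although (1-carboxy-2-methylbutyl)amino in place of (1-methylprop-2-yn-1-yl)oxy on a carbonyl carbon still gives an at least 2.5-fold lower number from compound 1 to compound 3 (0.39 log units; beyond the scatter). The value of compound 1 is a limit of the assay and not a number: the limit of > 50000 nM in this assay, at which 1 of the 3 values shown sits.

The whole group changes in this single step, with fewer heavy atoms, one double bond instead of two and one hydrogen-bond donor instead of none, so the compounds shown cannot tell which part of the change moves the number. As far as these compounds go, a methyl ester or an amine in place of the carboxylic acid of 1-carboxy-2-methylbutyl would help to separate the acid from the chain that carries it, and it remains open whether any other group on this nitrogen would give a lower number than compound 2.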